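A few compounds are considered here, and "the series" means these few. Any claim that something is new, unique, unknown or untested is made for them only; others in the source may bear on it.

Compound 1 `CCSc1sc(-n2nc(C)c(Cc3ccccc3[N+](=O)[O-])c2C(=O)O)nc1-c1ccc(Cl)c(Cl)c1` is one of two compounds examined here. In a functional assay on BJAB cells (Homo sapiens) for antiproliferative activity, with a stated time of 4 days (on this read-out lower numbers stand for an effect already at smaller amounts and higher numbers for an effect only at larger amounts of compound), compound 1 gives 59000 nM, the highest of the two numbers; compound 2 `Cc1nn(-c2nc(-c3ccc(Cl)c(Cl)c3)c(SC(C)C)s2)c(C(=O)O)c1-c1cnn(C)c1` gives 6800 nM, a much lower number in this assay, and the gap between these two values lies beyond the usual scatter. Compound 3 `CCSc1sc(-n2nc(C)c(Cc3ccccc3[N+](=O)[O-])c2C(=O)OC)nc1-c1ccc(Cl)c(Cl)c1` differs from compound 1 by methyl in place of hydrogen on an oxygen next to a carbonyl group. Among the compounds with values here, no measured pair shows the effect of this change, so the expected step from compound 1 to compound 3 is small and uncertain, estimated as a 1.4-fold higher number from compound 1 to compound 3 (0.13 log units; within the scatter). For compound 3 the estimated value in this assay is 80000 nM, with a range from 20000 nM to 300000 nM.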

Compound 3, half-maximal effective concentration: 106000 nM
Estimate against measurement, compound 3: 1.3-fold (0.12 log units) below, within the range that was stated.
By their numbers in this assay, from the lowest: compound 2; then compounds 1 and 3 (each within the scatter of the next).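

Within this assay the change from hydroxy to methoxy, which turns carboxy into methoxycarbonyl, gives a 1.8-fold higher number from compound 1 to compound 3 (0.25 log units; within the scatter) and so cannot be told apart from the scatter. At this oxygen, methyl can therefore take the place of hydrogen without a change that this read-out can resolve. No evidence is available that bears on this result. On these data alone, whether a longer chain, as in an ethyl ester, or an amide in place of the carboxy group would read the same remains open. So does whether this change gives the same result on the core of compound 2.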